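A few compounds are considered here, and "the series" means these few. Any claim that something is new, unique, unknown or untested is made for them only; others in the source may bear on it.

Measured compounds and their values:

- Compound 1, `Cc1cc(C2=NN(c3ccc(S(C)(=O)=O)cc3)C(=O)CC2)ccc1O`: 60.5%
- Compound 2, `CS(=O)(=O)c1ccc(N2N=C(c3ccccc3)CCC2=O)cc1`: 47.3%
- Compound 3, `CS(=O)(=O)c1ccc(N2N=C(c3ccc(Cl)c(Cl)c3)CCC2=O)cc1`: 34.2%

These three compounds share a core and differ only in the aromatic ring attached to the carbon that carries a double bond to nitrogen. In a functional assay on the whole organism (strain Wistar) for inhibition, with Rattus norvegicus as the target, read by paw edema, with stated times of 30 min and 5 h, at a dose of 0.05 mmol/kg by the oral route (a lower number here means less inhibition, a higher number more inhibition at the dose given (going by the name of the read-out)), compound 2 gives 47.3%, which places it second highest of the three numbers. Its steps to the other two are both beyond the scatter: a number 13.2 percentage points lower from compound 1 to compound 2 (beyond the scatter), and a number 13.1 percentage points lower from compound 2 to compound 3 (beyond the scatter). The longer step, a number 26.3 percentage points lower from compound 1 to compound 3 (beyond the scatter), spans the whole range seen so far.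

Compound 4, `CC(C)(C)c1ccc(C2=NN(c3ccc(S(C)(=O)=O)cc3)C(=O)CC2)cc1`, is the next compound in the series and has not yet been measured in this assay. It differs from compound 2 in a single place: tert-butyl in place of hydrogen on an aromatic carbon

Among the compounds with values here, no measured step adds a tert-butyl group, so none bears directly on this change. The two steps that do involve compound 2 show that substituents on this ring can move the number in either direction, with a 4-hydroxy-3-methylphenyl ring higher and a 3,4-dichlorophenyl ring lower than plain phenyl. From these, no step beyond the scatter in either direction can be argued for compound 4, so the expected step is a number 2.3 percentage points lower from compound 2 to compound 4 (within the scatter). Compound 4 is therefore estimated at 45%, within a range of 25% to 65% in this assay.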

Compound 4, a percentage reported as inhibition, in the whole organism at one dose (the size of the read-out at that dose, not a potency): 68.4%
Estimate against measurement, compound 4: 23.4 percentage points below; the whole stated range lies below it.
By their numbers in this assay, from the lowest: compound 3; then compound 2; then compounds 1 and 4 (each within the scatter of the next).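

Adding tert-butyl at this ring position, para to a large group, gives a number 21.1 percentage points higher from compound 2 to compound 4 (beyond the scatter) in this assay, so a substituent here can lift the number above that of plain phenyl. Before this, the only ring above plain phenyl was the 4-hydroxy-3-methylphenyl ring of compound 1, whereas tert-butyl is built of carbon alone, has no hydrogen-bond donors or acceptors, and still brings compound 4 within the scatter of compound 1, although adding to the ring is no general route upward, as compound 3 goes against that with a number 13.1 percentage points lower from compound 2 to compound 3 (beyond the scatter). Nothing available explains why tert-butyl has this effect.

The compounds shown leave open whether the rise depends on the size of the group at this carbon, which a smaller isopropyl group or a longer butyl chain could test. They also leave open how a methoxy group, an amine or a carboxylic acid at the same carbon would compare, and the single-dose read-out says nothing about potency.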